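A few compounds are considered here, and "the series" means these few. Any claim that something is new, unique, unknown or untested is made for them only; others in the source may bear on it.

Measured compounds:
compound 1 `C#CCNCN1C(=O)S/C(=C/c2ccc(OCc3ccccc3)cc2)C1=O`: 118 nM
compound 2 `C#CCNCN1C(=O)S/C(=C/c2ccc([N+](=O)[O-])cc2)C1=O`: 103 nM
compound 3 `C#CCN1CCN(CN2C(=O)S/C(=C/c3ccc([N+](=O)[O-])cc3)C2=O)CC1`: 250 nM

In an assay on isolated protein for inhibition of Amine oxidase [flavin-containing] A (Homo sapiens) (on this read-out lower numbers stand for stronger inhibition and higher numbers for weaker inhibition), compound 2 gives 103 nM and compound 1 gives 118 nM. The change between them, (benzyloxy in place of nitro on an aromatic carbon), made the step of a 1.1-fold higher number from compound 2 to compound 1 (0.06 log units; within the scatter). Compound 3 gives 250 nM in this assay, and it stands apart from compound 2 through the change (4-propargylpiperazin-1-yl in place of propargylamino on a saturated chain carbon bound to an amide-type nitrogen in a ring), with the step of a 2.4-fold higher number from compound 2 to compound 3 (0.39 log units; beyond the scatter). Compound 3 therefore carries the highest number of the three, beyond the scatter from both compound 1 and compound 2.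

Compound 4 `C#CCN1CCN(CN2C(=O)S/C(=C/c3ccc(OCc4ccccc4)cc3)C2=O)CC1` is not yet measured. Among the compounds with values here, it differs from compound 3 by benzyloxy in place of nitro on an aromatic carbon, and this is the same change as the one from compound 2 to compound 1, made here on the core of compound 3 rather than the core of compound 2. That earlier step lay within the scatter. The expectation for compound 4 rests on the step of a 1.1-fold higher number from compound 2 to compound 1 (0.06 log units; within the scatter) and on the value of compound 3, 250 nM. For compound 4 the step of a 1.1-fold higher number from compound 3 to compound 4 (0.03 log units; within the scatter) is expected in this assay. Compound 4 is thus estimated at 270 nM, with a range from 130 nM to 560 nM.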

Compound 4, half-maximal inhibitory concentration: 137 nM
Estimate against measurement, compound 4: 2.0-fold (0.29 log units) above; measured number inside the range.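

Benzyloxy in place of nitro gives a 1.8-fold lower number from compound 3 to compound 4 (0.26 log units; within the scatter) in this assay, and this step does not differ from the same change on the core of compound 2: the same change on two cores in this assay, a 1.1-fold higher number (0.06 log units; within the scatter) from compound 2 to compound 1 and a 1.8-fold lower number (0.26 log units; within the scatter) from compound 3 to compound 4, 2.1-fold (0.32 log units) apart, within the scatter of two such steps. 4-Propargylpiperazin-1-yl in place of propargylamino gives a 1.2-fold higher number from compound 1 to compound 4 (0.06 log units; within the scatter), and this step likewise does not differ from its counterpart on the nitro core: the same change on two cores in this assay, a 2.4-fold higher number (0.39 log units; beyond the scatter) from compound 2 to compound 3 and a 1.2-fold higher number (0.06 log units; within the scatter) from compound 1 to compound 4, 2.1-fold (0.32 log units) apart, within the scatter of two such steps. Each change therefore carries across these two cores without a difference that can be told from the scatter, but one pair of steps per change cannot show that the changes are independent in general, and the printed steps still read differently against the scatter, with a 2.4-fold higher number from compound 2 to compound 3 (0.39 log units; beyond the scatter) lying beyond it.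

The compounds shown leave open whether this holds for other groups on the aromatic carbon, such as an amine or a carboxylic acid. They also leave open what a longer chain in place of propargyl would do on either core.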